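A few compounds are considered here, and "the series" means these few. Any claim that something is new, unique, unknown or untested is made for them only; others in the source may bear on it.

All compounds in this series share one core and differ only in the aromatic group on a carbon with a double bond to nitrogen. In a functional assay on SW-620 cells (Homo sapiens) for cytotoxicity, read by sulforhodamine B assay, with a stated time of 48 h (on this read-out lower numbers stand for stronger inhibition and higher numbers for weaker inhibition), compound 1 `C[C@H]1CC[C@@H]2[C@@H](OC(=O)[C@]23CC(c2c(Cl)cccc2Cl)=NO3)[C@]2(C)C(=O)C=C[C@@]12O` gives 43000 nM and compound 2 `C[C@H]1CC[C@@H]2[C@@H](OC(=O)[C@]23CC(c2ccc([N+](=O)[O-])cc2)=NO3)[C@]2(C)C(=O)C=C[C@@]12O` gives 9000 nM. Compound 3 `COc1cc(C2=NO[C@]3(C2)C(=O)O[C@@H]2[C@H]3CC[C@H](C)[C@]3(O)C=CC(=O)[C@@]23C)ccc1O` gives 88000 nM, the highest of the three numbers and therefore the weakest inhibition among them.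

Compound 4 `Cc1ccccc1C1=NO[C@]2(C1)C(=O)O[C@@H]1[C@H]2CC[C@H](C)[C@]2(O)C=CC(=O)[C@@]12C` has 2-methylphenyl in place of the 4-hydroxy-3-methoxyphenyl of compound 3, at the same carbon, next to the ring nitrogen of a five-membered non-aromatic ring: 2-methylphenyl in place of 4-hydroxy-3-methoxyphenyl on a carbon with a double bond to nitrogen.

Three measured steps change the group at this place: a 4.8-fold lower number from compound 1 to compound 2 (0.68 log units; beyond the scatter), a 2.0-fold higher number from compound 1 to compound 3 (0.31 log units; beyond the scatter) and a 9.8-fold higher number from compound 2 to compound 3 (0.99 log units; beyond the scatter). Compound 3 has the higher number in both steps that involve it, so moving away from its group is expected to lower the number. By name, 2-methylphenyl looks closer to the 2,6-dichlorophenyl of compound 1, at 43000 nM, than to the 4-nitrophenyl of compound 2, at 9000 nM. This is only a loose guide, so a modest drop is expected rather than the full size of the larger step. The expected change is a 2.5-fold lower number from compound 3 to compound 4 (0.40 log units; beyond the scatter). For compound 4, the estimated value is 35000 nM, with an expected range of 12000 nM to 100000 nM.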

Compound 4, half-maximal inhibitory concentration: 5000 nM
Estimate against measurement, compound 4: 7.0-fold (0.85 log units) above; measured number below the stated range.
By their numbers in this assay, from the lowest: compounds 4 and 2 (each within the scatter of the next); then compound 1; then compound 3.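

In this assay, among these compounds, replacing 4-hydroxy-3-methoxyphenyl with 2-methylphenyl produces the only large step (an 18-fold lower number from compound 3 to compound 4 (1.25 log units; beyond the scatter)), so this position can shift the number further than the earlier compounds showed. The numbers also show that a 4-nitrophenyl group is not needed to reach the low end, since 2-methylphenyl, with 0 hydrogen-bond donors and 0 hydrogen-bond acceptors, stays level with it (a 1.8-fold lower number from compound 2 to compound 4 (0.26 log units; within the scatter)), while a similar name proves a poor guide, as 2-methylphenyl and 2,6-dichlorophenyl sit well apart (an 8.6-fold lower number from compound 1 to compound 4 (0.93 log units; beyond the scatter)). Nothing available here explains why the number moves with these changes at this position.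

As far as these compounds go, it remains open whether the methyl group of 2-methylphenyl contributes at all, a question that a plain phenyl group at the same carbon would address. It is also unclear which part of 4-hydroxy-3-methoxyphenyl goes with the high number of compound 3, which 4-hydroxyphenyl and 3-methoxyphenyl could separate, and how an amine or a carboxylic acid on the aromatic ring would behave.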